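Chloro to Methyl on the Amide Aryl of Compound 3

The compounds below may be only part of what the source reports. "The series", "measured", "known", "first", "only" and "open" are said of these compounds alone.

Compound 1 `Nc1ccccc1NC(=O)c1c(NO)cc(-c2ccccc2)oc1=O` gives > 20000 nM in an ADME assay on Huh-7 cells (Homo sapiens) for cytotoxicity, with a stated time of 3 days (a lower number here means that less compound is tolerated, a higher number that more compound is tolerated), a limit of the assay.
Compound 2 `O=C(NC1CCCCC1)c1c(NO)cc(-c2ccccc2)oc1=O` gives 10500 nM in this assay.
Compound 3 `O=C(Nc1ccc(Cl)cc1)c1c(NO)cc(-c2cccs2)oc1=O` gives > 20000 nM in this assay, a limit of the assay.

Going by the values given here, compound 3 thus sits at the limit of > 20000 nM in this assay, at which 2 of the 3 values shown sit, as does compound 1, while compound 2 is the only one with a number. Among the compounds with values here, the single measured step is an at least 1.9-fold lower number from compound 1 to compound 2 (0.27 log units; that floor lies within the scatter), a change on the amide nitrogen that leaves the aryl substituent untouched. Compound 4 `Cc1ccc(NC(=O)c2c(NO)cc(-c3cccs3)oc2=O)cc1` differs from compound 3 by methyl in place of chloro on an aromatic carbon. Within the data shown here, no measured step bears on this change, so no step beyond the scatter is expected, and compound 4 would most plausibly remain at the limit. The expected step is a step that the limit leaves unreadable from compound 3 to compound 4. Compound 4 is therefore estimated at 25000 nM, with a range from 10000 nM to 60000 nM.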

Compound 4, half-maximal cytotoxic concentration: > 20000 nM
Compound 4: only a limit was reported; the forecaster's own chance of this, stated with the estimate: 70%; the middle value is on the limit's open side.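

Compound 3 and compound 4 both stand at a limit of the assay rather than at a number, so no step can be read between them: the limit of > 20000 nM in this assay, at which 3 of the 4 values shown sit.

The compounds shown leave open whether methyl in place of chloro changes the result in this assay at all.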